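The source may hold more compounds than are shown below. What is called first, only, known or untested is meant among the compounds shown, and "the series" means these compounds.

Compound 1 `C=C[C@@](C)(/C=C/c1ccc(OS(=O)(=O)C(F)(F)F)cc1)CCC=C(C)C`: > 26000 nM
Compound 2 `C=C[C@@](C)(/C=C/c1ccc(OS(=O)(=O)c2ccc(C)cc2)cc1)CCC=C(C)C`: > 26000 nM
Compound 3 `CC(C)=CCC[C@](C)(/C=C/c1ccc(O)cc1)/C=C/c1cccc(Cl)c1`: > 26000 nM

In a functional assay on Raji cells (Homo sapiens) for cytotoxicity, with a stated time of 72 h (on this read-out lower numbers stand for an effect already at smaller amounts and higher numbers for an effect only at larger amounts of compound), compound 1 gives > 26000 nM, and this is a limit of the assay rather than a measured number. For compound 2 the result > 26000 nM is likewise a limit. Compound 3 also stops at a limit, > 26000 nM. So compound 1 stands, together with the other two, at the edge of what this assay could read, as the limit of > 26000 nM in this assay, at which 3 of the 3 values shown sit, records.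

Compound 4 `C=C[C@@](C)(/C=C/c1ccc(-c2ccc(Cl)c(Cl)c2)cc1)CCC=C(C)C` is the next compound. It differs from compound 1 in one place: 3,4-dichlorophenyl in place of ((trifluoromethyl)sulfonyl)oxy on an aromatic carbon.

Among the compounds with values here, the only step between two measured compounds is a step that the two limits leave unreadable from compound 1 to compound 2, which is between two limits and therefore tells nothing about its size. Within the data shown here, no measured step swaps a ((trifluoromethyl)sulfonyl)oxy group for a 3,4-dichlorophenyl group, so there is no evidence pointing to a direction for this change in this assay. Given that every measured compound sits at the same limit, the most plausible expectation is that compound 4 stays near that limit as well, with an expected step of an at least 1.3-fold lower number from compound 1 to compound 4 (0.11 log units; that floor lies within the scatter) that cannot be separated from the scatter. The estimate for compound 4 is therefore 20000 nM, spanning 4000 nM to 60000 nM.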

Compound 4, half-maximal effective concentration: > 26000 nM
Compound 4: no number, only a limit; the forecaster's own chance of this, stated with the estimate: 60%; at least 1.3-fold (0.11 log units) between middle value and limit.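

Compound 4 gives > 26000 nM and this too is a limit of the assay, not a number. Compound 1 also stopped at a limit, so the change from compound 1 to compound 4 cannot be read. Still open is how strongly any of these compounds acts in this assay and whether their differences matter, with all resting on one result: the limit of > 26000 nM in this assay, at which 4 of the 4 values shown sit.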